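Methoxy to trifluoromethyl exchange on the pendant aryl ring

A few compounds are considered here, and "the series" means these few. Any claim that something is new, unique, unknown or untested is made for them only; others in the source may bear on it.

Of the compounds shown here, three have been measured in an assay on isolated protein for inhibition of Amine oxidase [flavin-containing] B (Homo sapiens); a lower number here means a stronger inhibitor, a higher number a weaker inhibitor. Compound 1 `C#CCNC1CCc2c(SCCc3cccc(C(F)(F)F)c3)cccc21` gives 3720 nM. Compound 2 `C#CCNC1CCc2c(SCCc3cccc(OC)c3)cccc21` gives 28700 nM. Compound 3 `C#CCNC1CCc2c(SCCc3ccc(OC)cc3)cccc21` gives 62000 nM, the highest number of the three. Compound 2 and compound 3 have the same atoms joined differently; the difference is 4-methoxyphenyl in place of 3-methoxyphenyl on a saturated chain carbon, two bonds along the chain from a sulfur, and the step is a 2.2-fold higher number from compound 2 to compound 3 (0.33 log units; beyond the scatter). Compound 2 and compound 1 differ by trifluoromethyl in place of methoxy on an aromatic carbon, and the step is a 7.7-fold lower number from compound 2 to compound 1 (0.89 log units; beyond the scatter).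

Compound 4 `C#CCNC1CCc2c(SCCc3ccc(C(F)(F)F)cc3)cccc21` is not yet measured. It differs from compound 3 by trifluoromethyl in place of methoxy on an aromatic carbon. This is the same kind of change as that from compound 2 to compound 1, but the place differs: meta to a large group in compound 1, para to a large group in compound 4. Within the data shown here, the change has occurred once among the measured compounds, so only one step is available to lean on. Resting on the value of compound 3 in this assay and on the step of a 7.7-fold lower number from compound 2 to compound 1 (0.89 log units; beyond the scatter), the step expected for compound 4 is a 6.9-fold lower number from compound 3 to compound 4 (0.84 log units; beyond the scatter). The value expected for compound 4 in this assay is 9000 nM, most likely between 3000 nM and 30000 nM.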

Compound 4, half-maximal inhibitory concentration: 16100 nM
For compound 4 the middle estimate is 1.8-fold (0.25 log units) below the measured one; low and high end bracket the measured number.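

In this assay, trifluoromethyl in place of methoxy, para to a large group, gives a 3.9-fold lower number from compound 3 to compound 4 (0.59 log units; beyond the scatter). Set beside the earlier exchange, meta to a large group, the size of the step holds within the scatter: the same change on two cores in this assay, a 7.7-fold lower number (0.89 log units; beyond the scatter) from compound 2 to compound 1 and a 3.9-fold lower number (0.59 log units; beyond the scatter) from compound 3 to compound 4, 2.0-fold (0.30 log units) apart, within the scatter of two such steps. Among these compounds, this supports carrying the exchange between these two closely related cores, in direction and in approximate size, but it rests on only two steps and shows neither why the number falls nor whether the same step would appear on a core that differs more widely.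

Still open, from the compounds shown here alone, is whether the exchange keeps its direction and size when the two-carbon chain to the aryl ring gives way to a longer chain, or when the sulfur gives way to an oxygen or an amide. Also open, going by these compounds, is how a chlorine or a nitrile on the pendant aryl ring would compare with trifluoromethyl and methoxy.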